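Saturated ring in place of phenyl on the two-carbon chain

The compounds below may be only part of what the source reports. "The series", "measured", "known", "first", "only" and "open" are said of these compounds alone.

Compound 3 `O=C(O)c1ccccc1-c1ccc(CCc2ncc(CCc3ccccc3)[nH]2)cc1` stands second highest of the three numbers in an in vitro functional assay on cells for agonist activity at Bombesin receptor subtype-3 (Homo sapiens), read by luminescence and calcium flux; on this read-out lower numbers stand for an effect already at smaller amounts and higher numbers for an effect only at larger amounts of compound; compound 3 gives 1320 nM. Compound 1 `O=C(O)c1ccccc1-c1ccc(CCc2ncc(CC3CCCC3)[nH]2)cc1` gives 133 nM, and compound 2 `COc1ccc(Cc2cnc(CCc3ccc(-c4ccccc4C(=O)O)cc3)[nH]2)cc1` gives 5360 nM. The steps run a 9.9-fold higher number from compound 1 to compound 3 (1.00 log units; beyond the scatter), a 40-fold higher number from compound 1 to compound 2 (1.61 log units; beyond the scatter) and a 4.1-fold lower number from compound 2 to compound 3 (0.61 log units; beyond the scatter), so the cyclopentyl-bearing compound 1 sits well below both aromatic-bearing compounds in this assay. Compound 4 `O=C(O)c1ccccc1-c1ccc(CCc2ncc(CCC3CCCCC3)[nH]2)cc1` arises from compound 3 by cyclohexyl in place of phenyl on a saturated chain carbon, two bonds along the chain from an aromatic carbon. Within the data shown here, the steps that bear on it are those from compound 1, which exchange cyclopentyl for an aromatic group on the chain: the number rose a 9.9-fold higher number from compound 1 to compound 3 (1.00 log units; beyond the scatter) and a 40-fold higher number from compound 1 to compound 2 (1.61 log units; beyond the scatter). Running the exchange the other way, aromatic to non-aromatic ring, compound 4 is therefore expected to give a lower number in this assay, with a step of modest size, since the chain length and ring size do not match those of compound 1 exactly. The estimated step is a 3.3-fold lower number from compound 3 to compound 4 (0.52 log units; beyond the scatter). Compound 4 is expected at 400 nM, within a range from 100 nM to 1500 nM.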

Compound 4, half-maximal effective concentration: 642 nM
Compound 4: the middle estimate sits 1.6-fold (0.21 log units) below what was measured; low and high end bracket the measured number.
By their numbers in this assay, from the lowest: compound 1; then compound 4; then compound 3; then compound 2.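

With the chain held as it is, phenethyl to 2-cyclohexylethyl gives a step in this assay that lies beyond the scatter (a 2.1-fold lower number from compound 3 to compound 4 (0.31 log units; beyond the scatter)), so a non-aromatic ring of the same heavy-atom count is favoured over phenyl at this position as well as on the cyclopentyl side of the series. The cyclohexyl compound also lies well clear of the 4-methoxyphenyl compound (an 8.3-fold lower number from compound 2 to compound 4 (0.92 log units; beyond the scatter)), yet it does not reach the cyclopentyl compound (a 4.8-fold higher number from compound 1 to compound 4 (0.68 log units; beyond the scatter)), so saturation alone does not account for the whole range of numbers seen here. Nothing at hand gives a reason for these steps.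

As far as these compounds go, what remains open is whether cyclopentyl on this same chain would give a lower number than cyclohexyl, which would separate ring size from chain length. From the compounds shown here alone, it is also open how an amine or a hydroxyl on the cyclohexyl ring, or a longer chain, would shift the number.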